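A few compounds are considered here, and "the series" means these few. Any claim that something is new, unique, unknown or untested is made for them only; others in the source may bear on it.

Series notes on a physicochemical assay for solubility, with a stated time of 18 h, at pH 7.4; a lower number here means a less soluble compound, a higher number a more soluble compound. Compound 1 `COc1cccc(CNCCCNc2ccnc3cc(CCC(C)C)ccc23)c1O` gives 4200 nM in this assay. Compound 2 `Fc1ccc(Cc2ccc3c(NCCCNCc4ccco4)ccnc3c2)c(Cl)c1` gives 4200 nM, and compound 3 `COc1ccc(F)cc1CNCCCNc1ccnc2cc(Cc3ccc(F)cc3Cl)ccc12` gives 4200 nM. Compound 2 thus stands level with compounds 1 and 3 at the digits recorded: its reading is within the scatter of that of compound 1 and within the scatter of that of compound 3. Among the measured compounds shown here, the only single-point step among the measured compounds, no change at the digits printed from compound 2 to compound 3 (within the scatter), swaps the group on the saturated chain carbon bound to the amine nitrogen and leaves the reading where it was.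

Compound 4 `c1coc(CNCCCNc2ccnc3cc(CC4CCCCC4)ccc23)c1` is not yet measured. It differs from compound 2 at the other end of the molecule: cyclohexyl in place of 2-chloro-4-fluorophenyl on a saturated chain carbon bound to an aromatic carbon. For the measured compounds named here, no measured step touches this position, so the only guidance is the flat run across compounds 1, 2 and 3, which carry different groups at both ends yet all sit at one value. On that basis no step beyond the scatter is expected, the estimated step being no change at the digits printed from compound 2 to compound 4 (within the scatter). For compound 4 the expected value in this assay is 4200 nM, with a range of 1500 nM to 12000 nM.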

Compound 4, solubility: 4200 nM
Estimate against measurement, compound 4: no gap at the digits printed, and the stated range covers the measured number.
By their numbers in this assay, from the lowest: compounds 1, 2, 3 and 4 (each within the scatter of the next).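

In this assay the position on a saturated chain carbon bound to an aromatic carbon now has its own measured step: no change at the digits printed from compound 2 to compound 4 (within the scatter) on going to cyclohexyl in place of 2-chloro-4-fluorophenyl. This single change takes out the aromatic ring, the chlorine and the fluorine together, and the reading stays within the scatter, so for this pair neither the aromatic ring nor the two halogens are needed to hold the value. With the earlier step at the furan-2-yl end, each end of the molecule now has one single-place change on compound 2, and neither step goes beyond the scatter, though no data here explain this flat behaviour.

The shared printed value leaves open whether any group at this position can move the reading, since only 2-chloro-4-fluorophenyl and cyclohexyl have been compared there in a single-place step. A ring bearing an amine or a carboxylic acid in place of cyclohexyl, or a longer chain between that ring and the core of compound 4, would test this position with groups unlike the carbon-only rings compared so far.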